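Sulfonyl for carbamate on the bridged amine: expected maximal response

This account rests on a few compounds, and the source may have more. Where it says the series, first, only, none or still open, it means among the compounds named here.

Measured compounds:
compound 1 `Cc1c(Nc2ccc(C#N)cc2Cl)ncnc1OC1C2COCC1CN(C(=O)OC1(C)CC1)C2` — 102%
compound 2 `CC1(OC(=O)N2CC3COCC(C2)C3Oc2cc(Nc3ccc(C#N)cc3Cl)ncn2)CC1` — 105%

In a functional assay on HEK293 cells for agonist activity at Glucose-dependent insulinotropic receptor (Mus musculus), read by fluorescence and cAMP accumulation, with a stated time of 30 min (on this read-out higher numbers stand for larger maximal responses and lower numbers for smaller maximal responses), compound 1 gives 102%. Compound 2, which carries hydrogen in place of methyl on an aromatic carbon, gives 105%. Compound 1 thus holds the lowest of the two numbers, with compound 2 nearest, and the step of a number 3 percentage points higher from compound 1 to compound 2 (within the scatter) lies within the scatter, so the two compounds are not told apart on this read-out.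

Compound 3 `Cc1c(Nc2ccc(C#N)cc2Cl)ncnc1OC1C2COCC1CN(S(=O)(=O)C1CC1)C2` differs from compound 1 in one place: cyclopropylsulfonyl in place of ((1-methylcyclopropyl)oxy)carbonyl on an amine nitrogen in a ring.

Going by the values given here, no measured step touches the group on the amine nitrogen in a ring; the only step in hand, a number 3 percentage points higher from compound 1 to compound 2 (within the scatter), concerns the aromatic methyl and is within the scatter. Both measured compounds reach a full maximal response, and nothing in the data points to a change in that behaviour for compound 3. The step of a number 2 percentage points lower from compound 1 to compound 3 (within the scatter) is therefore expected to stay within the scatter. Compound 3 is estimated at 100%, with a range of 85% to 112%.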

Compound 3, largest response reached (reported as percent of maximum), in percent of the reference or control that the assay uses: 53%
For compound 3 the middle estimate is 47 percentage points above the measured one, outside the stated range (below it).
By their numbers in this assay, from the lowest: compound 3; then compounds 1 and 2 (each within the scatter of the next).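

In this assay, going by these compounds alone, the exchange of ((1-methylcyclopropyl)oxy)carbonyl for cyclopropylsulfonyl on the amine nitrogen in a ring gives a number 49 percentage points lower from compound 1 to compound 3 (beyond the scatter), so this position can set the maximal response, whereas the only earlier change, at the aromatic carbon, gave a number 3 percentage points higher from compound 1 to compound 2 (within the scatter). The large step comes with a swap that keeps the three-membered carbon ring, the count of hydrogen-bond acceptors and donors and the absence of net charge, so these shared features alone do not preserve the full response seen with compound 1. No measurement bearing on the origin of this loss is available.

The compounds shown do not separate the part played by the sulfonyl link from that of the lost methyl and the lost oxygen, a question that a 1-methylcyclopropylsulfonyl group or a cyclopropylcarbonyl amide on the same nitrogen would address. They also leave open whether hydrogen in place of the aromatic methyl would remain without consequence alongside cyclopropylsulfonyl, as it does alongside the carbamate.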